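Flipping One Stereocentre in Compound 3

The source may hold more compounds than are shown below. What is called first, only, known or untested is meant among the compounds shown, and "the series" means these compounds.

In a functional assay on K562 cells (Homo sapiens) for cytotoxicity, read by MTT assay (on this read-out lower numbers stand for higher toxicity in this test and higher numbers for lower toxicity in this test), compound 1 (`COC(=O)C(C)(O)[C@](O)(C[C@H](C)CCC/C(C)=C/CC/C(C)=C/CCc1ccoc1)C(=O)OC`) gives 20 ug/mL as its reading. Compound 2 (`COC1C=C(CCC/C(C)=C\CC/C(C)=C\CC[C@@H](C)/C=C2\OC(=O)C(C)=C2O)C(OC)O1`) gives 83 ug/mL in the same test, and compound 3 (`COC(=O)C(C)(O)[C@@](O)(C[C@H](C)CC/C=C(/C)CC/C=C(/C)CCCc1ccoc1)C(=O)OC`) gives 46 ug/mL there. Compound 3 cannot be told apart from compound 2, as their two values lie within the usual scatter. Compound 1 has a lower number than compound 3, beyond the scatter, and so counts as more toxic in this test.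

Compound 4 (`COC(=O)C(C)(O)[C@](O)(C[C@H](C)CC/C=C(/C)CC/C=C(/C)CCCc1ccoc1)C(=O)OC`) differs from compound 3 at a single place (the two compounds have the same atoms and bonds; at least one stereo element is drawn with a configuration in one of them and without one in the other: 1 of 5 stereo elements differ; a stereocentre at a saturated chain carbon is drawn S in compound 3 and R in compound 4). The two compounds have the same atoms and bonds, but a stereocentre at a saturated chain carbon is drawn S in compound 3 and R in compound 4. Within the data shown here, no measured pair here differs in this way alone, so the data do not show how much such a change matters. The expectation therefore starts from compound 3 with 46 ug/mL as its reading. In this assay the expected move is small and within the scatter, and the estimate is a 1.2-fold lower number from compound 3 to compound 4 (0.08 log units; within the scatter) as a slight lean toward a lower number. For compound 4 the estimated value is 38 ug/mL with an expected range from 17 ug/mL to 85 ug/mL for this reading.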

Compound 4, concentration lethal to 50% of the cells: 34 ug/mL
For compound 4 the middle estimate is 1.1-fold (0.05 log units) above the measured one; low and high end bracket the measured number.
By their numbers in this assay, from the lowest: compounds 1, 4, 3 and 2 (each within the scatter of the next, the first and the last beyond it).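

Among these compounds, this is the first pair that differs at one place only, so the stereocentre at a saturated chain carbon, drawn S in compound 3 and R in compound 4, can now be looked at on its own. In this assay this change gives a 1.4-fold lower number from compound 3 to compound 4 (0.13 log units; within the scatter), so the two compounds cannot be told apart, and for this pair the configuration drawn at this carbon leaves no mark on the reading that stands clear of the usual scatter. This rests on a single pair and carries one caution about how far it can be read as a clean swap of one configuration for the other: the fact that one of compounds 3 and 4 is drawn with a defined configuration and the other without, at the place where they differ

As far as these compounds go, whether the two configurations would still read alike on a molecule that also carried a carboxylic acid or an amine stays open, as one pair says nothing about how this carbon behaves once the rest of the structure is altered. Also open, from the compounds shown here alone, is whether the same two compounds would stay equally close on cells other than those of this test, or in a read-out of a different kind.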